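This account rests on a few compounds, and the source may have more. Where it says the series, first, only, none or still open, it means among the compounds named here.

Toxicity to human cells is the question here. In a functional assay on MT4 cells (Homo sapiens), read by MTT assay (on this read-out higher numbers stand for lower toxicity in this test and lower numbers for higher toxicity in this test), compound 1 (`C#C[C@]1(CO)OC(N2C=CC(N)NC2=O)[C@@H](O)[C@@H]1O`) gives 1740 nM. Compound 2 (`C#C[C@]1(CO)O[C@@H](n2cc(CC)c(=O)[nH]c2=O)C[C@@H]1O`) stands at a limit of the test, > 360000 nM, and so has no exact number. Compound 3 (`C#C[C@]1(CO)O[C@@H](n2cc(F)c(=O)[nH]c2=O)C[C@@H]1O`) differs from compound 2 by one change: fluoro in place of ethyl on an aromatic carbon. For the measured compounds named here, no measured pair shows what this swap does, so any expectation must be loose. Compound 1, at 1740 nM, shows that a clearly measurable toxicity can appear among these structures. A move towards higher toxicity, meaning a lower number in this assay, is therefore expected, although a result at the limit remains possible. The expected size of the change is an at least 18-fold lower number from compound 2 to compound 3 (1.25 log units; beyond the scatter). For compound 3 the estimated value is 20000 nM, with an expected range of 1000 nM to 360000 nM.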

Compound 3, half-maximal cytotoxic concentration: 3400 nM
Compound 3: the middle estimate sits 5.9-fold (0.77 log units) above what was measured; measured number inside the range.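

At this position on the six-membered aromatic ring, fluoro in place of ethyl turns a compound without an exact toxicity number into one with a clear reading in this assay and gives an at least 100-fold lower number from compound 2 to compound 3 (2.02 log units; beyond the scatter) for this single swap. Until now, no pair of compounds had shown what any one change does to toxicity, and here a swap of one group on an aromatic carbon is enough to produce a large step. The step is only a minimum, because compound 2 has a limit and not a number: the limit of > 360000 nM in this assay, at which 1 of the 3 values shown sits.

Ethyl and fluoro are the only groups shown at this position, so it remains open whether the step belongs to fluoro alone or to the loss of ethyl. A methyl group, a chlorine atom or a longer chain such as propyl at the same place would help to separate these two readings.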